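A few compounds are considered here, and "the series" means these few. Any claim that something is new, unique, unknown or untested is made for them only; others in the source may bear on it.

Compound 2 `N#Cc1c(-c2ccc(Cl)cc2)cc(-c2ccc(Cl)cc2)n([C@@H]2O[C@H](CO)[C@@H](O)[C@H]2O)c1=O` gives 6.9 ug/mL in a functional assay on HepG2 cells (Homo sapiens) for cytotoxicity, read by sulforhodamine B assay, with a stated time of 48 h (a higher number here means a weaker inhibitor, a lower number a stronger inhibitor), the lowest of the three numbers. Compound 3 `CC(=O)OC[C@H]1O[C@@H](n2c(-c3ccc(Cl)cc3)cc(-c3ccc(Cl)cc3)c(C#N)c2=O)[C@H](OC(C)=O)[C@@H](OC(C)=O)[C@@H]1OC(C)=O` gives 7.25 ug/mL, within the scatter of compound 2, while compound 1 `C#CCn1c(-c2ccc(Cl)cc2)cc(-c2ccc(Cl)cc2)c(C#N)c1=O` gives 18.3 ug/mL, a gap beyond the scatter. Compound 4 `N#Cc1c(-c2ccc(Cl)cc2)cc(-c2ccc(Cl)cc2)n(CC2CO2)c1=O` differs from compound 2 by (oxiran-2-yl)methyl in place of 3,4-dihydroxy-5-(hydroxymethyl)oxolan-2-yl on an aromatic nitrogen. Among the measured compounds shown here, one measured step bears on this change: swapping propargyl for 3,4-dihydroxy-5-(hydroxymethyl)oxolan-2-yl gave a 2.7-fold lower number from compound 1 to compound 2 (0.42 log units; beyond the scatter). Putting a small group, (oxiran-2-yl)methyl, back in place of that ring is therefore expected to move the number partly back toward compound 1, a modest rise rather than none. Compound 4 is expected to give 14 ug/mL, likely between 7 ug/mL and 28 ug/mL, an estimated step of a 2.0-fold higher number from compound 2 to compound 4 (0.31 log units; beyond the scatter).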

Compound 4, half-maximal inhibitory concentration: 6.2 ug/mL
Estimate against measurement, compound 4: 2.3-fold (0.35 log units) above, outside the stated range (below it).
By their numbers in this assay, from the lowest: compounds 4, 2 and 3 (each within the scatter of the next); then compound 1.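

At this aromatic nitrogen, (oxiran-2-yl)methyl in place of the larger 3,4-dihydroxy-5-(hydroxymethyl)oxolan-2-yl, with no hydrogen-bond donors, gives a 1.1-fold lower number from compound 2 to compound 4 (0.05 log units; within the scatter) in this assay, so that hydroxyl-bearing ring is not needed to reach this number. Small size alone does not set the number either: oxiran-2-yl in place of ethynyl on the saturated chain carbon gives a 3.0-fold lower number from compound 1 to compound 4 (0.47 log units; beyond the scatter). Nothing measured here gives a reason for these differences. Going by these compounds, whether the three-membered ring itself matters stays open; a plain propyl chain or an aminoethyl chain on this nitrogen would address that.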